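The source may report more compounds than this note shows. Statements on the series, on what has been measured and on what is new or still open speak of the compounds shown alone.

Measured in an ADME assay on S9 fraction from liver (Rattus norvegicus), read by LC-MS, with a stated time of 60 min, at 37 degrees C; on this read-out higher numbers stand for a more stable compound and lower numbers for a less stable compound:
compound 1 `CC(C)COC(=O)N1CCN(C(=O)c2nc(Nc3cc(C4CC4)[nH]n3)c3cc(Cl)ccc3n2)C[C@H]1C` gives 61.1%;
compound 2 `CC(OC(=O)N1CCN(C(=O)c2nc(Nc3cc(C4CC4)[nH]n3)c3cc(Cl)ccc3n2)C[C@H]1C)OC(=O)C(C)(C)C` gives 66.3%;
compound 3 `COC(=O)N1CCN(C(=O)c2nc(Nc3cc(C4CC4)[nH]n3)c3cc(Cl)ccc3n2)C[C@H]1C` gives 34.2%.

Compound 3 stands lowest of the three measured compounds. Compound 4 `C[C@@H]1CN(C(=O)c2nc(Nc3cc(C4CC4)[nH]n3)c3cc(Cl)ccc3n2)CCN1C(=O)OCOC(=O)C(C)(C)C` differs from it by ((tert-butyl)carbonyl)oxy in place of hydrogen on a saturated chain carbon bound to an oxygen next to a carbonyl group. Among the measured compounds shown here, two measured steps bear on this change. Going from a larger to a smaller group on that oxygen gave a number 32.1 percentage points lower from compound 2 to compound 3 (beyond the scatter), and the related step gave a number 26.9 percentage points lower from compound 1 to compound 3 (beyond the scatter). The change to compound 4 runs the other way, turning the methyl of compound 3 into (((tert-butyl)carbonyl)oxy)methyl, so a rise in this assay is expected, with a step of about a number 27.8 percentage points higher from compound 3 to compound 4 (beyond the scatter). Compound 4 is therefore estimated at 62%, with a range from 45% to 78%.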

Compound 4, percent of the compound remaining: 47%
Beside the measured number, compound 4's estimate is 15 percentage points above it; the range from low to high includes it.
By their numbers in this assay, from the lowest: compound 3; then compound 4; then compounds 1 and 2 (each within the scatter of the next).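

In this assay, putting ((tert-butyl)carbonyl)oxy on the saturated chain carbon gives a number 12.8 percentage points higher from compound 3 to compound 4 (beyond the scatter), a real gain but a partial one. A single methyl matters here: replacing it with hydrogen on the carbon bound to two oxygens gives a number 19.3 percentage points lower from compound 2 to compound 4 (beyond the scatter). Using ((tert-butyl)carbonyl)oxy in place of isopropyl gives a number 14.1 percentage points lower from compound 1 to compound 4 (beyond the scatter), so this group alone does not match the isobutyl compound.

No available evidence accounts for these differences. As far as these compounds go, how an amine or a carboxylic acid on this carbon would behave remains open.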